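Cyclobutyl for cyclopropyl: expecting a modest shift

The source may hold more compounds than are shown below. What is called first, only, known or untested is meant among the compounds shown, and "the series" means these compounds.

Measured in a functional assay on aorta (Rattus norvegicus) for inhibition; on this read-out higher numbers stand for an effect only at larger amounts of compound and lower numbers for an effect already at smaller amounts:
Compound 1 `CCNC1=NS(=O)(=O)c2cc(Cl)ccc2N1`: 39900 nM
Compound 2 `O=S1(=O)N=C(NC2CC2)Nc2ccc(Cl)cc21`: 191000 nM

Of these two numbers, compound 2 stands higher at 191000 nM. The change from compound 2 to compound 3 `O=S1(=O)N=C(NC2CCC2)Nc2ccc(Cl)cc21` is cyclobutyl in place of cyclopropyl on an amine nitrogen. For the measured compounds named here, only one measured step bears on it: a 4.8-fold higher number from compound 1 to compound 2 (0.68 log units; beyond the scatter), a modest one, which put cyclopropyl in place of ethyl on the same amine nitrogen. Going by the values given here, no measurement yet covers cyclobutyl, so a modest step towards a lower number is tentatively expected in this assay. The estimated step is a 2.7-fold lower number from compound 2 to compound 3 (0.44 log units; beyond the scatter). Compound 3 is expected at 70000 nM. Its estimated range runs from 18000 nM to 250000 nM.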

Compound 3, half-maximal effective concentration: 34900 nM
Compound 3: middle estimate off by 2.0-fold (0.30 log units), on the high side; the measured number falls inside the stated range.
By their numbers in this assay, from the lowest: compounds 3 and 1 (each within the scatter of the next); then compound 2.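

In this assay a carbon ring on this amine nitrogen does not by itself bring a higher number: cyclobutyl gives a 5.5-fold lower number from compound 2 to compound 3 (0.74 log units; beyond the scatter) and so cancels what cyclopropyl showed. Set against ethyl, cyclobutyl gives a 1.1-fold lower number from compound 1 to compound 3 (0.06 log units; within the scatter) and leaves compound 3 level with compound 1, so that among these three only compound 2 stands apart. Nothing at hand explains why cyclopropyl alone differs. Still open, as far as these compounds go, is how a larger ring such as cyclopentyl or a branched chain such as isopropyl would read at this place.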